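A few compounds are considered here, and "the series" means these few. Any claim that something is new, unique, unknown or untested is made for them only; others in the source may bear on it.

Compound 1 `CCNCc1cc(C)cc(Nc2nc3ccccc3n2Cc2ccc(C(F)(F)F)cc2)c1O` gives 18800 nM
Compound 2 `CCN(CC)Cc1cc(C)cc(Nc2nc3ccccc3n2Cc2ccc(C(F)(F)F)cc2)c1O` gives 29300 nM
Compound 3 `CCN(CC)Cc1cc(C)cc(Nc2nc3ccccc3[nH]2)c1O` gives > 50000 nM (a limit, not a number)

In an ADME assay on CHO cells (Cricetulus griseus) for inhibition, read by MTT assay (on this read-out lower numbers stand for stronger inhibition and higher numbers for weaker inhibition), compound 2 gives 29300 nM and lies within the scatter of compound 1. Compound 3 offers only its limit for comparison. Compound 4 `Cc1cc(CN)c(O)c(Nc2nc3ccccc3n2Cc2ccc(C(F)(F)F)cc2)c1` departs from compound 2 by amino in place of diethylamino on a saturated chain carbon bound to an aromatic carbon. The closest measured change is on that same amine nitrogen, ethyl in place of hydrogen, a 1.6-fold higher number from compound 1 to compound 2 (0.19 log units; within the scatter), and it stays small. The change on the aromatic nitrogen, an at least 1.7-fold higher number from compound 2 to compound 3 (0.23 log units; that floor lies within the scatter), lies elsewhere and bears little on this one. In this assay the expected result is a 1.8-fold lower number from compound 2 to compound 4 (0.26 log units; within the scatter), with no step beyond the scatter. Compound 4 is expected at 16000 nM, with an estimated range of 6500 nM to 38000 nM.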

Compound 4, half-maximal inhibitory concentration: 47600 nM
Compound 4: middle estimate off by 3.0-fold (0.47 log units), on the low side; measured number above the stated range.
By their numbers in this assay, from the lowest: compounds 1, 2 and 4 (each within the scatter of the next, the first and the last beyond it). At a limit, above all of these: compound 3.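

In this assay, amino in place of diethylamino on a saturated chain carbon bound to an aromatic carbon gives a 1.6-fold higher number from compound 2 to compound 4 (0.21 log units; within the scatter). Hydrogen in place of ethyl on the amine nitrogen gives a 2.5-fold higher number from compound 1 to compound 4 (0.40 log units; beyond the scatter), the first step at this position to pass the scatter, so only the ethyl and amino forms are separated here. Little room remains above compound 4 on this read-out: the limit of > 50000 nM in this assay, at which 1 of the 4 values shown sits.

From the compounds shown here alone, whether a propyl chain or a piperidine on this carbon would stay with compound 1 or move towards compound 4 remains open.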